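The compounds below may be only part of what the source reports. "The series", "measured", "known", "first", "only" and "open" are said of these compounds alone.

Measured compounds:
- compound 1 `COc1ccc(C(=O)c2sc(Nc3ccc(F)cc3)c(C(=O)O)c2C)cc1`: 10.5%
- compound 2 `Cc1ccc(Nc2sc(C(=O)c3ccc(C)cc3)c(C)c2C(=O)O)cc1`: "not active" (no number reported)

In a functional assay, with a stated time of 150 min, tested at 30 ug/mL (on this read-out higher numbers stand for a stronger effect at the one concentration tested and lower numbers for a weaker effect), compound 1 gives 10.5%. Compound 2 stands without a single number in this assay, recorded only as "not active" (no number reported). Compound 3 `Cc1ccc(C(=O)c2sc(Nc3ccc(F)cc3)c(C(=O)O)c2C)cc1` is not yet measured. It differs from compound 2 by fluoro in place of methyl on an aromatic carbon. Within the data shown here, with no measured step for this pair, the change is expected to move the read-out little, if at all, beyond the scatter, and in no firm direction. For compound 3 the activity in this assay is estimated at 8%, within 0% to 20%.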

Compound 3, a percentage reported as activity, at one concentration (the size of the read-out at that concentration, not a potency): "not active" (no number reported)
Compound 3 has no reported number here, so the estimate cannot be set against anything.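

In this assay compound 2 and compound 3 are both recorded only as not active, so no step can be read between them. On these data alone, whether fluoro in place of methyl changes this read-out stays open, and nothing available bears on the result.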